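The source may report more compounds than this note shows. Statements on the series, on what has been measured and on what is new or still open speak of the compounds shown alone.

In an ADME assay on microsomes from liver (Homo sapiens) for metabolic stability, read by LC-MS, using NADPH, with a stated time of 1 h, tested at 10 uM (on this read-out lower numbers stand for slow clearance and higher numbers for fast clearance), compound 2 (`Cn1nc(CN2CCCC2)nc1-c1ccc(C(C)(C)C)cc1`) gives 5.8 mL.min-1.g-1. This value stands within the usual scatter of the two other measured compounds. Compound 1 (`Cn1nc(CN2CCCC2)nc1-c1ccc(C2(C(F)(F)F)CC2)cc1`) gives 4 mL.min-1.g-1, and compound 3 (`Cn1nc(CN2CCCC2)nc1-c1cccc(C2(C(F)(F)F)CC2)c1`) gives 7.9 mL.min-1.g-1. Compound 2 therefore starts from a group of close numbers rather than from an extreme.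

The next compound is compound 4 (`CN(Cc1nc(-c2ccc(C(C)(C)C)cc2)n(C)n1)CC1CC1`), which keeps the tert-butyl group of compound 2 and alters the other end of the molecule: (cyclopropylmethyl)(methyl)amino in place of pyrrolidin-1-yl on a saturated chain carbon bound to an aromatic carbon. In short, (cyclopropylmethyl)(methyl)amino stands in place of pyrrolidin-1-yl on a saturated chain carbon bound to an aromatic carbon.

Within the data shown here, only one measured step links two compounds that differ in a single place, a 1.5-fold higher number from compound 1 to compound 2 (0.16 log units; within the scatter). It lies within the scatter and concerns the group on an aromatic carbon, so it bears on this change only indirectly. All three measured compounds carry pyrrolidin-1-yl, and the data therefore hold no direct measure of replacing it. With so little to go on, the expectation is a small move towards a higher number, with a wide margin on either side.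

The expected change is a 1.3-fold higher number from compound 2 to compound 4 (0.11 log units; within the scatter), which is estimated to stay within the scatter. In this assay, the estimate for compound 4 is 7.5 mL.min-1.g-1, with the measurement expected to fall between 3.8 mL.min-1.g-1 and 15 mL.min-1.g-1.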

Compound 4, intrinsic clearance in microsomes: 11.3 mL.min-1.g-1
Estimate against measurement, compound 4: 1.5-fold (0.18 log units) below; the range from low to high includes it.
By their numbers in this assay, from the lowest: compounds 1, 2, 3 and 4 (each within the scatter of the next, the first and the last beyond it).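

With tert-butyl kept in place, the replacement of pyrrolidin-1-yl by (cyclopropylmethyl)(methyl)amino on a saturated chain carbon bound to an aromatic carbon gives, in this assay, a 1.9-fold higher number from compound 2 to compound 4 (0.29 log units; within the scatter), and this is the one direct measure of a change at this end of the molecule among the compounds shown. It shows that the five-membered non-aromatic ring on this carbon can give way to an open amine carrying a three-membered ring of carbon only, with one more heavy atom, and that the read-out stays within the scatter, although this single pair cannot establish a trend for the position. Nothing measured here accounts for the size or direction of this step, so it stands as an observation without an explanation.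

Still open, going by these compounds, is whether other groups in this place, such as dimethylamino, morpholin-4-yl or piperidin-1-yl, would also stay within the scatter of compound 2. Equally open, on these data alone, is whether (cyclopropylmethyl)(methyl)amino would give a similar step with 1-(trifluoromethyl)cyclopropyl on the aromatic carbon in place of tert-butyl.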